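Sulfur substituent swap on the naphthyl chalcone core

This account rests on a few compounds, and the source may have more. Where it says the series, first, only, none or still open, it means among the compounds named here.

Compound 2 `Cc1cc(Nc2ccc(C(=O)/C=C/c3ccc4ccccc4c3)cc2)n2nc(SC(=O)c3csc4ccc(Cl)cc34)nc2n1` carries a 2-naphthyl group on the chain and a (5-chloro-1-benzothiophen-3-yl)carbonyl group on the sulfur; in a functional assay on SW-620 cells (Homo sapiens) for cytotoxicity, read by MTT assay, with stated times of 4 h and 72 h, tested at 2 uM (a lower number here means a stronger inhibitor, a higher number a weaker inhibitor), compound 2 gives 35 nM, the lowest of the three numbers measured, and the strongest inhibitor of the set. Compound 1 `Cc1cc(Nc2ccc(C(=O)/C=C/c3ccccc3F)cc2)n2nc(SCc3nc4ccccc4[nH]3)nc2n1` gives 250 nM and compound 3 `Cc1cc(Nc2ccc(C(=O)/C=C/c3ccc(Br)cc3)cc2)n2nc(SCc3nc4ccccc4[nH]3)nc2n1` gives 290 nM in this assay; both carry a benzimidazolylmethyl group on the sulfur. Among the compounds with values here, the one measured single-point step, a 1.2-fold higher number from compound 1 to compound 3 (0.06 log units; within the scatter), concerns the aryl group on the chain and lies within the scatter.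

Compound 4 `Cc1cc(Nc2ccc(C(=O)/C=C/c3ccc4ccccc4c3)cc2)n2nc(SCC(=O)c3ccccc3)nc2n1` is to be measured in this assay. It differs from compound 2 in one place: benzoylmethyl in place of (5-chloro-1-benzothiophen-3-yl)carbonyl on a sulfur. Within the data shown here, no measured step bears on the sulfur substituent alone; compounds 1 and 3 differ from compound 2 both on the sulfur and on the chain aryl group, so their gap to compound 2 cannot be split between the two sites. Among the measured compounds shown here, the change from compound 2 to compound 4 therefore rests on no direct precedent, and a moderate rise in the number is the expectation, a 2.9-fold higher number from compound 2 to compound 4 (0.46 log units; beyond the scatter), with wide uncertainty. Compound 4 is estimated at 100 nM, with a range from 35 nM to 300 nM.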

Compound 4, half-maximal inhibitory concentration: 190 nM
For compound 4 the middle estimate is 1.9-fold (0.28 log units) below the measured one; the range from low to high includes it.
By their numbers in this assay, from the lowest: compound 2; then compounds 4, 1 and 3 (each within the scatter of the next).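

With the 2-naphthyl group on the chain held fixed, the sulfur substituent can now be read alone: in this assay the change gives a 5.4-fold higher number from compound 2 to compound 4 (0.73 log units; beyond the scatter), so this position on the sulfur affects the number by more than the scatter, which compounds 1 and 3 could not show because they also differ on the chain aryl group. The step is a single exchange of whole groups, with 12 heavy atoms leaving and 9 entering; the chlorine, the ring sulfur and the five-membered aromatic ring all go at once, so no one of these features can be credited with the rise. No measured data on the compounds explain the difference.

Open, going by these compounds, is whether the (5-chloro-1-benzothiophen-3-yl)carbonyl group would keep its advantage over benzoylmethyl with 2-fluorophenyl or 4-bromophenyl on the chain. Also open, on these data alone, is how far the number depends on the chlorine itself, and how the sulfur position would respond to an amine or a carboxylic acid on the benzoylmethyl phenyl ring.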